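The source may hold more compounds than are shown below. What is called first, only, known or untested is meant among the compounds shown, and "the series" means these compounds.

Compound 1 `CN1CC[C@H](c2c(O)cc(O)c3c(=O)cc(/C=C/c4ccc(Cl)cc4)oc23)[C@H](O)C1`: in a functional assay on HL-60 cells (Homo sapiens) for inhibition, read by MTT assay, with a stated time of 48 h (a higher number here means a weaker inhibitor of growth, a lower number a stronger inhibitor of growth), compound 1 gives 8000 nM.
Compound 2 `CN1CC[C@H](c2c(O)cc(O)c3c(=O)cc(/C=C/c4c(F)c(F)c(F)c(F)c4F)oc23)[C@H](O)C1`: in this assay compound 2 gives 3000 nM.

Among the compounds with values here, of these two numbers, compound 2 holds the lower one; the only measured step, a 2.7-fold lower number from compound 1 to compound 2 (0.43 log units; beyond the scatter), separates it from compound 1. Compound 3 `CN1CC[C@H](c2c(O)cc(O)c3c(=O)cc(/C=C/c4ccccc4F)oc23)[C@H](O)C1` has not yet been measured. It differs from compound 2 in one place: 2-fluorophenyl in place of 2,3,4,5,6-pentafluorophenyl on a double-bonded chain carbon bound to a double-bonded chain carbon. The measured step bears on this, since it also swapped the ring on the double-bonded chain carbon, and there the 2,3,4,5,6-pentafluorophenyl gave the lower number. Within the data shown here, compound 3 keeps a single fluorine on that ring and gives up the other four, and no measured compound carries a 2-fluorophenyl, so the expectation rests on that one step alone. A modest move back toward the number of compound 1 is expected, a 2.0-fold higher number from compound 2 to compound 3 (0.30 log units; within the scatter). For compound 3 the estimate in this assay is 6000 nM, with a range of 2500 nM to 14000 nM.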

Compound 3, concentration for 50% growth inhibition: 8000 nM
For compound 3 the middle estimate is 1.3-fold (0.12 log units) below the measured one; the measured number falls inside the stated range.
By their numbers in this assay, from the lowest: compound 2; then compounds 1 and 3 (each within the scatter of the next).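

In this assay, a second comparison now bears on the ring on the double-bonded chain carbon: going from the 2,3,4,5,6-pentafluorophenyl with five fluorines to the 2-fluorophenyl with one gives a 2.7-fold higher number from compound 2 to compound 3 (0.43 log units; beyond the scatter) and cancels the earlier advantage of the 2,3,4,5,6-pentafluorophenyl. Replacing the 4-chlorophenyl with the 2-fluorophenyl gives no change at the digits printed from compound 1 to compound 3 (within the scatter) and so separates these two rings by nothing that can be read. Among these three compounds, only the 2,3,4,5,6-pentafluorophenyl stands apart.

These compounds leave open whether the number of fluorines or their places on the ring matters, since no compound carries two, three or four of them. As far as these compounds go, it also remains open how a ring bearing a methoxy group or an amine would compare. No measurement here explains these differences.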